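Cytotoxicity after a Side-Chain Swap

The source may hold more compounds than are shown below. What is called first, only, known or untested is meant among the compounds shown, and "the series" means these compounds.

Compound 1, `CCC1(Cc2ccccc2)OS(=O)(=O)C=C1OCCCCc1ccccc1`, was measured in an ADME assay on HEL cells (Homo sapiens) for cytotoxicity, with a stated time of 3 days (on this read-out lower numbers stand for higher toxicity in this test and higher numbers for lower toxicity in this test), where compound 1 reaches only a limit of >= 20000 nM.
Compound 2, `C=CCOC1=CS(=O)(=O)OC1(CC)Cc1ccccc1`, gives 80000 nM in this assay.

Among the compounds with values here, compound 2 thus holds the only actual number in this assay; the one other value is a limit. Between these two compounds a single change was made, and its effect on toxicity cannot be read: a step that the limit leaves unreadable from compound 1 to compound 2, since the limit of >= 20000 nM in this assay, at which 1 of the 2 values shown sits, hides where compound 1 truly sits.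

Compound 3, `CCC1(Cc2ccccc2)OS(=O)(=O)C=C1OCCCc1ccccc1`, is the next step from compound 2. The change is phenethyl in place of vinyl on a saturated chain carbon bound to an oxygen on an unsaturated carbon. Within the data shown here, the only measured step at the same place is the one from compound 1 to compound 2, and its size is not readable, so it gives no direction. Phenethyl sits between vinyl and 3-phenylpropyl in chain length, so compound 3 is expected to land between its two neighbours, and the step of a 1.8-fold lower number from compound 2 to compound 3 (0.25 log units; within the scatter) is expected to stay modest. The estimate for compound 3 in this assay is 45000 nM, within 15000 nM to 130000 nM.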

Compound 3, minimum cytotoxic concentration: >= 20000 nM
Compound 3: only a limit was reported (the forecaster's own chance of this, stated with the estimate: 40%); the middle value lies beyond the limit too.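

No step among compound 1, compound 2 and compound 3 can be read in this assay, because each step involves at least one value that is only a limit: the limit of >= 20000 nM in this assay, at which 2 of the 3 values shown sit.

The compounds shown leave open whether phenethyl or 3-phenylpropyl in place of vinyl changes toxicity at all, and how compound 1 and compound 3 compare.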